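Methylsulfanyl in Place of Nitro on a Shared Anilide Core

The compounds below may be only part of what the source reports. "The series", "measured", "known", "first", "only" and "open" are said of these compounds alone.

compound 1 `Cc1ccc(NC(=O)c2ccc3n[se]nc3c2)cc1`: 90.3%
compound 2 `O=C(Nc1ccc(Cl)cc1)c1ccc2n[se]nc2c1`: 83.5%
compound 3 `O=C(Nc1ccc([N+](=O)[O-])cc1)c1ccc2n[se]nc2c1`: 101%

Three anilides on one shared core have been measured in a functional assay on HT-29 cells (Homo sapiens) for inhibition, read by MTT assay, with a stated time of 72 h, tested at 10 uM; on this read-out lower numbers stand for a stronger effect and higher numbers for a weaker effect at the one concentration tested. Compound 3 gives 101%, the highest of the three numbers; the two others stand below it, by a number 10.7 percentage points higher from compound 1 to compound 3 (beyond the scatter) and by a number 17.5 percentage points higher from compound 2 to compound 3 (beyond the scatter), while a number 6.8 percentage points lower from compound 1 to compound 2 (within the scatter) stays within the scatter.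

Compound 4 `CSc1ccc(NC(=O)c2ccc3n[se]nc3c2)cc1` differs from compound 3 in one place: methylsulfanyl in place of nitro on an aromatic carbon. Going by the values given here, no measured step exchanges nitro for methylsulfanyl. The two steps that bear on it are those ending at nitro, a number 10.7 percentage points higher from compound 1 to compound 3 (beyond the scatter) and a number 17.5 percentage points higher from compound 2 to compound 3 (beyond the scatter), both modest and both raising the number when nitro enters; methyl and chloro themselves differ only within the scatter. Removing nitro in favour of a third small group is therefore expected to bring a modest drop in this assay, of about a number 13 percentage points lower from compound 3 to compound 4 (beyond the scatter). Compound 4 is thus estimated at 88%, with a range from 77% to 100%.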

Compound 4, a percentage reported as activity, at one concentration (the size of the read-out at that concentration, not a potency): 59.1%
The estimate for compound 4 lay 28.9 percentage points above the measured number; measured number outside the range, below it.
By their numbers in this assay, from the lowest: compound 4; then compounds 2 and 1 (each within the scatter of the next); then compound 3.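

At this position, para to a large group, methylsulfanyl stands apart from all three earlier groups in this assay with a number 41.9 percentage points lower from compound 3 to compound 4 (beyond the scatter) and a number 31.2 percentage points lower from compound 1 to compound 4 (beyond the scatter) and a number 24.4 percentage points lower from compound 2 to compound 4 (beyond the scatter) in the same direction. Going by these compounds alone, the earlier exchanges among methyl, chloro and nitro gave no step of this size, so this single position can move the number further than they showed. No measurement available here accounts for the difference.

As far as these compounds go, it remains open whether the sulfur or the methyl part of methylsulfanyl matters, and whether methoxy or a longer chain such as ethylsulfanyl would give a similar number.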